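This account rests on a few compounds, and the source may have more. Where it says the series, first, only, none or still open, it means among the compounds named here.

Working notes on the series.

Compound 1 `C/C=C1/[C@H](O[C@@H]2O[C@H](CO)[C@@H](O)[C@H](O)[C@H]2O)OC=C(C(=O)OC)[C@H]1CC(=O)OCCC1CCCCC1` is the reference point here. Going by the values given here, in a functional assay on SK-BR-3 cells (Homo sapiens) for antiproliferative activity, read by MTT assay, with a stated time of 72 h (a lower number here means a stronger inhibitor, a higher number a weaker inhibitor), compound 1 gives 2000 nM, the only proper number in the set so far. Among the compounds with values here, the one further value is a limit of the assay: the limit of > 15000 nM in this assay, at which 1 of the 2 values shown sits. Compound 2 `C/C=C1/[C@H](O[C@@H]2O[C@H](COC(C)=O)[C@@H](OC(C)=O)[C@H](OC(C)=O)[C@H]2OC(C)=O)OC=C(C(=O)OC)[C@H]1CC(=O)OCC` sits at that limit, returning > 15000 nM in this assay, so no number is known for it.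

Compound 3 `C/C=C1/[C@H](O[C@@H]2O[C@H](CO)[C@@H](O)[C@H](O)[C@H]2O)OC=C(C(=O)OC)[C@H]1CC(=O)OCCCC` is not yet measured. It differs from compound 1 in one place: ethyl in place of cyclohexyl on a saturated chain carbon, two bonds along the chain from an oxygen next to a carbonyl group. Within the data shown here, no measured pair in the set shares this change, so the size of the step is open. The working expectation is a loss of activity from compound 1 to compound 3 of about a 2.5-fold higher number from compound 1 to compound 3 (0.40 log units; beyond the scatter), somewhat beyond the usual scatter. Compound 3 is therefore estimated at 5000 nM in this assay, with a range from 1500 nM to 15000 nM.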

Compound 3, half-maximal inhibitory concentration: > 15000 nM
Compound 3 ended at the assay's limit (the forecaster's own chance of this, stated with the estimate: 25%); middle value at least 3.0-fold (0.47 log units) from the limit.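

The position is not indifferent to its group: ethyl in place of cyclohexyl gives an at least 7.5-fold higher number from compound 1 to compound 3 (0.87 log units; beyond the scatter) in this assay. On these data alone, for compound 3, > 15000 nM is a limit of the assay and not a number, so the full size of this step remains unknown. Compound 3 now sits at the same limit as compound 2: the limit of > 15000 nM in this assay, at which 2 of the 3 values shown sit.

This single pair changes the ring and the heavy-atom count together, and it does not show which of the two matters. Also open, as far as these compounds go, is how a longer chain such as octyl, a phenyl ring or a terminal amine would read at this place, and whether any group here improves on compound 1, at 2000 nM.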